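Nitro in place of hydrogen across two cores

The source may report more compounds than this note shows. Statements on the series, on what has been measured and on what is new or still open speak of the compounds shown alone.

Compound 1 `COc1cc(NC(=O)c2ccc(Cl)cc2)ccc1NS(C)(=O)=O` gives 70000 nM in an ADME assay on RAW264.7 cells (Mus musculus) for cytotoxicity, read by MTT assay, with a stated time of 48 h; a lower number here means a stronger inhibitor, a higher number a weaker inhibitor. Compound 2 `COc1cc(NC(=O)c2ccc(Cl)c([N+](=O)[O-])c2)ccc1NS(C)(=O)=O` is its analogue carrying (nitro in place of hydrogen on an aromatic carbon); compound 2 reaches only a limit of this assay, > 250000 nM. The step of an at least 3.5-fold higher number from compound 1 to compound 2 (0.55 log units; beyond the scatter) is therefore a bound rather than a measured size, because the limit of > 250000 nM in this assay, at which 1 of the 3 values shown sits, caps what can be read.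

Compound 3 `O=C(Nc1ccc(NS(=O)(=O)C(F)(F)F)c(F)c1)c1ccc(Cl)cc1` belongs to a different core; the difference between the two cores is not broken down here. In this assay compound 3 gives 3270 nM, the lowest of the two numbers recorded.

Compound 4 `O=C(Nc1ccc(NS(=O)(=O)C(F)(F)F)c(F)c1)c1ccc(Cl)c([N+](=O)[O-])c1` carries nitro in place of hydrogen on an aromatic carbon, the same change as seen from compound 1 to compound 2, at the same place. Going by the values given here, since that change gave a higher number in the one pair measured, compound 4 is expected to sit higher than compound 3, with an estimated step of a 4.0-fold higher number from compound 3 to compound 4 (0.60 log units; beyond the scatter). The estimate for compound 4 is 13000 nM, expected between 4000 nM and 60000 nM.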

Compound 4, half-maximal inhibitory concentration: 188000 nM
The estimate for compound 4 lay 14-fold (1.16 log units) below the measured number; measured number above the stated range.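

In this assay, nitro in place of hydrogen on an aromatic carbon gives a higher number on both cores, and on the core with the trifluoromethyl sulfonamide the size can be read in full: a 57-fold higher number from compound 3 to compound 4 (1.76 log units; beyond the scatter). Going by these compounds alone, the direction of the change therefore carries over from one core to the other, though this rests on only one pair per core and says nothing about the series beyond these four compounds. Whether the size carries over cannot be said, because compound 2 stands at a limit of this assay and not at a measured number: the same change on two cores in this assay, an at least 3.5-fold higher number (0.55 log units; beyond the scatter) from compound 1 to compound 2 and a 57-fold higher number (1.76 log units; beyond the scatter) from compound 3 to compound 4; the limit leaves it open whether they differ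

The compounds shown leave open whether an amine or a carboxylic acid at the same place, ortho to the chloro group, would move the number in the same way as nitro. They also leave open whether the nitro step would hold on a core other than these two, or with a hydrogen in place of the chloro group.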